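From compound 3 to compound 4: the phenyl leaves

A few compounds are considered here, and "the series" means these few. Any claim that something is new, unique, unknown or untested is made for them only; others in the source may bear on it.

In an ADME assay on MT4 cells (Homo sapiens) for cytotoxicity (a lower number here means that less compound is tolerated, a higher number that more compound is tolerated), compound 3 `FC(F)(F)c1cccc(NC(=S)Nc2ccccc2)c1` gives 39000 nM, level with compound 1 `CC[C@H]1CC[C@H](c2ccc(NC(=S)Nc3cccc(C(F)(F)F)c3)cc2)CC1` at 39000 nM, while compound 2 `N#Cc1ccc(NC(=S)Nc2cccc(C(F)(F)F)c2)cc1` gives 7000 nM. Compound 4 `CSCCCNC(=S)Nc1cccc(C(F)(F)F)c1` is not yet measured. It carries 3-(methylsulfanyl)propyl in place of phenyl on an amide-type nitrogen.

Going by the values given here, no measured step makes this change, so the evidence is indirect. All three steps alter a group on an aromatic carbon. The step of no change at the digits printed from compound 1 to compound 3 (within the scatter) stays within the scatter, whereas a 5.6-fold lower number from compound 1 to compound 2 (0.75 log units; beyond the scatter) and a 5.6-fold higher number from compound 2 to compound 3 (0.75 log units; beyond the scatter) are modest and both involve the cyano group of compound 2, which compound 4 lacks. Compound 3 at 39000 nM is therefore the anchor, and no step beyond the scatter is expected in this assay, although the untested nature of the change keeps the range wide. The expected change is a 1.3-fold lower number from compound 3 to compound 4 (0.11 log units; within the scatter). The estimate for compound 4 is 30000 nM, with an expected range from 10000 nM to 90000 nM.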

Compound 4, half-maximal cytotoxic concentration: 43000 nM
Estimate against measurement, compound 4: 1.4-fold (0.16 log units) below; the range from low to high includes it.
By their numbers in this assay, from the lowest: compound 2; then compounds 1, 3 and 4 (each within the scatter of the next).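

In this assay the change on the amide-type nitrogen from phenyl to 3-(methylsulfanyl)propyl gives a 1.1-fold higher number from compound 3 to compound 4 (0.04 log units; within the scatter) and so stays within the scatter, although an aromatic ring leaves and an open chain containing sulfur enters. Going by these compounds alone, all earlier steps altered a group on an aromatic carbon, so this is the only reading at the nitrogen, and it shows that the phenyl of compound 3 is not required to keep this level in the assay. No measurement shown accounts for the result.

Going by these compounds, whether the level holds for other groups on this nitrogen, such as a shorter alkyl chain, a chain ending in an amine or one ending in a carboxylic acid, stays open. Also open, on these data alone, is whether the sulfur of compound 4 contributes anything, which its carbon-only chain analogue would test.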